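The source may report more compounds than this note shows. Statements on the series, on what has been measured and on what is new or still open speak of the compounds shown alone.

In a functional assay on MOLT-4 cells (Homo sapiens) for antiproliferative activity, read by MTT assay, with a stated time of 48 h (on this read-out lower numbers stand for stronger inhibition and higher numbers for weaker inhibition), compound 1 (`O=C(/C=C/c1ccc(Cn2cc(Nc3ncc(Cl)c(Nc4ccc(F)cc4)n3)cn2)cc1)NO`) gives 330 nM and compound 2 (`O=C(CCCCCCn1cc(Nc2ncc(Cl)c(Nc3cccc(Cl)c3)n2)cn1)NO`) gives 130 nM while compound 3 (`COc1ccc(Nc2nc(Nc3cnn(CCCCCCC(=O)NO)c3)ncc2Cl)cc1`) gives 170 nM on the same read-out. Compound 3 lies within the scatter of both compound 2 and compound 1. Compound 4 (`CNc1nc(Nc2cnn(CCCCCCC(=O)NO)c2)ncc1Cl`) is still unmeasured and differs from compound 3 as follows: methyl in place of 4-methoxyphenyl on a nitrogen on an aromatic ring. Among the measured compounds shown here, the only measured step at this place (a 1.3-fold higher number from compound 2 to compound 3 (0.12 log units; within the scatter)) exchanges 3-chlorophenyl for 4-methoxyphenyl and stays within the scatter. For the measured compounds named here, no measured step removes the ring, so the size here is a judgement. The expected move (a 2.6-fold higher number from compound 3 to compound 4 (0.42 log units; beyond the scatter)) in this assay is toward a higher number. For compound 4 the estimated value is 450 nM with an expected range from 160 nM to 1300 nM on this read-out.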

Compound 4, half-maximal inhibitory concentration: 110 nM
Estimate against measurement, compound 4: 4.1-fold (0.61 log units) above, outside the stated range (below it).
By their numbers in this assay, from the lowest: compounds 4, 2, 3 and 1 (each within the scatter of the next, the first and the last beyond it).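

In this assay the aromatic ring on this nitrogen is not needed for the read-out: a 1.5-fold lower number from compound 3 to compound 4 (0.19 log units; within the scatter) and a 1.2-fold lower number from compound 2 to compound 4 (0.07 log units; within the scatter) both stay within the scatter, although methyl brings a single heavy atom. The earlier step only exchanged one substituted phenyl for another, whereas these steps remove the ring altogether. Nothing available bears on why the ring can be lost in this assay.

Open, going by these compounds, is whether an unsubstituted amino group or a longer alkyl chain on this nitrogen would stay within the scatter of methyl. Also open, on these data alone, is whether methyl is tolerated alongside the side chain of compound 1.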